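The compounds below may be only part of what the source reports. "The series", "measured", "known", "first", "only" and "open" are said of these compounds alone.

In a functional assay on BT-474 cells (Homo sapiens) for inhibition, read by fluorescence, with a stated time of 72 h (a lower number here means a stronger inhibitor of growth, a higher number a weaker inhibitor of growth), compound 1 `CCCCn1cnc2c(NCc3cccc(Cl)c3)nc(N[C@H]3CC[C@H](N)CC3)nc21` gives 4700 nM and compound 2 `CC(C)CCn1cnc2c(Nc3cccc(Cl)c3)nc(N[C@H]3CC[C@H](N)CC3)nc21` gives 3800 nM while compound 3 `CCCCn1cnc2c(Nc3ccc(Cl)cc3)nc(N[C@H]3CC[C@H](N)CC3)nc21` gives 7300 nM as its reading. These three numbers all lie within the usual scatter of one another, so compound 3 cannot be told apart from the other two here.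

Compound 4 `CCCCn1cnc2c(Nc3cccc(Cl)c3)nc(N[C@H]3CC[C@H](N)CC3)nc21` holds the same atoms as compound 3, joined differently: 3-chlorophenyl in place of 4-chlorophenyl on a nitrogen on an aromatic ring sums up the change, with 3-chlorophenyl in place of 4-chlorophenyl on a nitrogen on an aromatic ring. For the measured compounds named here, no measured pair shows this exact swap. The nearest evidence is a 1.6-fold higher number from compound 1 to compound 3 (0.19 log units; within the scatter) on a nitrogen on an aromatic ring, with 4-chlorophenyl in place of 3-chlorobenzyl. That is a different swap, so it offers only indirect guidance, and it stayed within the scatter. No step beyond the scatter is therefore expected in this assay from this change, and the direction is only a weak guess, toward the middle of the three measured numbers. The expected change is a 1.5-fold lower number from compound 3 to compound 4 (0.16 log units; within the scatter) and it remains within the scatter. For compound 4 the estimated value is 5000 nM within an expected range from 2500 nM to 10000 nM.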

Compound 4, concentration for 50% growth inhibition: 5100 nM
Compound 4: middle estimate off by 1.0-fold (0.01 log units), on the low side, and the stated range covers the measured number.
By their numbers in this assay, from the lowest: compounds 2, 1, 4 and 3 (each within the scatter of the next).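

In this assay the swap of 4-chlorophenyl for 3-chlorophenyl on the nitrogen can now be read directly, and it gives a 1.4-fold lower number from compound 3 to compound 4 (0.16 log units; within the scatter), so these two placements of the chlorine cannot be told apart in this test. Compound 4 also links to the other two compounds, each through a single change: hydrogen in place of methyl on the saturated chain gives a 1.3-fold higher number from compound 2 to compound 4 (0.13 log units; within the scatter), and 3-chlorophenyl in place of 3-chlorobenzyl on the nitrogen gives a 1.1-fold higher number from compound 1 to compound 4 (0.04 log units; within the scatter). Among these four compounds, then, neither the methyl on the chain nor the choice between the 3-chlorobenzyl, 3-chlorophenyl and 4-chlorophenyl groups moves the number beyond the scatter.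

These compounds leave open whether a group of a different kind on the phenyl ring, such as a nitrile, a methoxy group or a carboxylic acid, would give a step beyond the scatter. Nothing at hand offers an explanation for how little these changes alter the number.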